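Triazole series: cytotoxicity notes, N-aryl variation

The source may hold more compounds than are shown below. What is called first, only, known or untested is meant among the compounds shown, and "the series" means these compounds.

Measured so far:
compound 1, `Oc1cc(C(F)(F)F)ccc1-c1nc(-c2ccccc2O)n(-c2ccc(I)cc2)n1`, 105%
compound 2, `Oc1cc(C(F)(F)F)ccc1-c1nc(-c2ccccc2O)n(-c2ccc(OC(F)(F)F)cc2)n1`, 92.5%
compound 3, `N#Cc1ccc(-n2nc(-c3ccc(C(F)(F)F)cc3O)nc2-c2ccccc2O)cc1`, 98.9%

In a functional assay on PC-12 cells (Rattus norvegicus) for cytotoxicity, read by MTT assay, with stated times of 2 h and 24 h, tested at 10 uM (on this read-out lower numbers stand for a weaker effect and higher numbers for a stronger effect at the one concentration tested), compound 3 sits within the scatter of both compound 1 and compound 2. Going by the values given here, only one step, a number 12.5 percentage points lower from compound 1 to compound 2 (beyond the scatter), went beyond the scatter; the steps of a number 6.1 percentage points lower from compound 1 to compound 3 (within the scatter) and a number 6.4 percentage points higher from compound 2 to compound 3 (within the scatter) did not. Compound 4, `Oc1cc(C(F)(F)F)ccc1-c1nc(-c2ccccc2O)n(-c2ccccc2F)n1`, carries the change (2-fluorophenyl in place of 4-cyanophenyl on an aromatic nitrogen). Every measured step altered the same aryl group on the ring nitrogen, and all three values stay high, so no step beyond the scatter is expected here. Compound 4 is estimated at 96%, with a range from 82% to 108%. The expected step is a number 2.9 percentage points lower from compound 3 to compound 4 (within the scatter).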

Compound 4, a percentage reported as activity, at one concentration (the size of the read-out at that concentration, not a potency): 100%
The estimate for compound 4 lay 4 percentage points below the measured number; the measured number falls inside the stated range.
By their numbers in this assay, from the lowest: compounds 2, 3, 4 and 1 (each within the scatter of the next, the first and the last beyond it).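

In this assay, 2-fluorophenyl on the aromatic nitrogen gives steps within the scatter against all three 4-substituted phenyl groups: a number 1.1 percentage points higher from compound 3 to compound 4 (within the scatter), a number 7.5 percentage points higher from compound 2 to compound 4 (within the scatter) and a number 5 percentage points lower from compound 1 to compound 4 (within the scatter). Moving the substituent from the 4-substituted pattern to a 2-fluoro group therefore leaves this read-out unresolved from all three earlier compounds, and compound 4 does not separate the pair that differs beyond the scatter. No available data explain this result. Open, on these data alone, is whether an amine or a carboxylic acid on this phenyl, or a longer chain in its place, would shift the read-out.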